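The source may report more compounds than this note shows. Statements on the series, on what has been measured and on what is new or still open speak of the compounds shown alone.

Measured compounds:
- compound 1, `CCN(Cc1ccncc1)C(=S)SCc1ccc(C(=O)Nc2ccccc2N)cc1`: 86.2%
- compound 2, `Nc1ccccc1NC(=O)c1ccc(CSC(=S)N2CCN(Cc3ccncc3)CC2)cc1`: 89.5%
- compound 3, `CC1CCN(C(=S)SCc2ccc(C(=O)Nc3ccccc3N)cc2)CC1`: 87.4%

All three were tested in a functional assay on A-375 cells (Homo sapiens) for antiproliferative activity, read by CCK-8 assay, with a stated time of 72 h, tested at 8 uM; on this read-out higher numbers stand for a stronger effect at the one concentration tested and lower numbers for a weaker effect. Compound 2 gives the highest of the three numbers in this assay, but the differences to compound 3 and to compound 1 are both within the scatter, so the three compounds cannot be ranked against one another.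

Compound 4, `Nc1ccccc1NC(=O)c1ccc(CSC(=S)N2CCN(c3ccncc3)CC2)cc1`, has not been measured. It differs from compound 2 in one place: pyridin-4-yl in place of (pyridin-4-yl)methyl on an amine nitrogen in a ring. Within the data shown here, the only step between measured compounds is a number 1.2 percentage points higher from compound 1 to compound 3 (within the scatter), which swapped the whole group on the thiocarbonyl carbon and barely moved the read-out. That step does not touch the same position as the change from compound 2 to compound 4, so it gives only indirect guidance; still, the three measured compounds, carrying quite different groups at this end of the molecule, all sit close together. No step beyond the scatter is therefore expected, a number 2.5 percentage points lower from compound 2 to compound 4 (within the scatter). Compound 4 is estimated to give 87% in this assay, between 74% and 95%.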

Compound 4, a percentage reported as inhibition, at one concentration (the size of the read-out at that concentration, not a potency): 90.7%
Beside the measured number, compound 4's estimate is 3.7 percentage points below it; measured number inside the range.
By their numbers in this assay, from the lowest: compounds 1, 3, 2 and 4 (each within the scatter of the next).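

At this position, in this assay, pyridin-4-yl in place of (pyridin-4-yl)methyl on an amine nitrogen in a ring gives a number 1.2 percentage points higher from compound 2 to compound 4 (within the scatter), the first step among these compounds to touch this position directly. On this read-out, the pyridine ring can therefore sit directly on the ring nitrogen or be joined to it through the carbon of the methyl link, with no step beyond the scatter between the two. No measurement shown here offers an explanation for this result.

The read-out comes from one concentration and is not a potency. Compound 2 and compound 4 could still differ at other concentrations. Going by these compounds, it also remains open how this assay would respond to a longer chain ending in pyridin-4-yl, or to a phenyl ring or a carboxylic acid on the same nitrogen.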